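Cytotoxicity notes on the imidazolylmethyl-aniline series

The compounds below may be only part of what the source reports. "The series", "measured", "known", "first", "only" and "open" are said of these compounds alone.

The series is followed in a toxicity assay on NIH3T3 cells (Mus musculus) for cytotoxicity, read by resazurin assay; a lower number here means that less compound is needed, a higher number that more compound is needed for the effect. Compound 1 `CC(C)c1ccc(Cn2cncc2CNc2ccc(-c3nc4ccccc4s3)c(-c3ccccc3)c2)cc1` reaches only the limit of the assay in this assay, with compound 1 at > 1000 nM, which is a limit and not a number. Compound 3 `COc1ccc(NCc2cncn2Cc2ccc(-c3ccccc3)cc2N)cc1-c1ccccc1` likewise stops at the limit, with compound 3 at > 1000 nM, again a limit rather than a measured value. Among the measured compounds shown here, compound 2 `COC(=O)c1ccc(NCc2cncn2Cc2ccccc2N)cc1-c1ccccc1` is the one member with a number in this assay, where compound 2 gives 25000 nM. For the measured compounds named here, that makes compound 2 the only point against which a step can be set; the other two values sit at the limit of > 1000 nM in this assay, at which 2 of the 3 values shown sit, so no measured step between compounds is available.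

Compound 4 `COC(=O)c1ccc(NCc2cncn2Cc2ccc(-c3ccccc3)cc2)cc1-c1ccccc1` has not been measured in this assay. Its change from compound 2 is 4-phenylphenyl in place of 2-aminophenyl on a saturated chain carbon bound to an aromatic nitrogen.

Expectation for this assay: with no measured step to rest on, no direction beyond the scatter is expected, and a result at the limit of the assay rather than a number is a real possibility. Given compound 2 at 25000 nM, compound 4 is expected to give about 20000 nM, in a range from 5000 nM to 60000 nM. The step this implies, from compound 2 to compound 4, is expected to be a 1.3-fold lower number from compound 2 to compound 4 (0.10 log units; within the scatter), within the usual scatter.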

Compound 4, half-maximal effective concentration: > 1000 nM
Compound 4: a limit, no number; the forecaster's own chance of this, stated with the estimate: 60%; the middle value does not contradict the limit.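

In this assay compound 4 stops at > 1000 nM, a limit and not a number, so the step from compound 2 to compound 4 cannot be read: the limit of > 1000 nM in this assay, at which 3 of the 4 values shown sit.

The compounds shown leave open whether 4-phenylphenyl in place of 2-aminophenyl changes the number at all, and in which direction, with compound 2 still the only member carrying a number.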